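A few compounds are considered here, and "the series" means these few. Any claim that something is new, unique, unknown or untested is made for them only; others in the source may bear on it.

Compound 1 `CCC1(c2ccccc2)CC(=O)C(C(CC(=O)c2ccc(-c3ccc(Br)cc3)cc2)c2ccccc2)=C(O)O1` gives 8130 nM in a functional assay on A549 cells (Homo sapiens) for inhibition, with a stated time of 72 h; a lower number here means a stronger inhibitor, a higher number a weaker inhibitor. Compound 2 `CCCC1(c2ccccc2)CC(=O)C(C(CC(=O)c2ccc(-c3ccc(Br)cc3)cc2)c2ccccc2)=C(O)O1` reaches only the limit of > 10000 nM in this assay, which is a limit of the method and not a number. Compound 3 `CC1(c2ccccc2)CC(=O)C(C2CC(c3ccc(-c4ccc(Br)cc4)cc3)Cc3ccccc32)=C(O)O1` gives 1830 nM in this assay.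

Compound 3 therefore holds the lowest of the two numbers; compound 1 shows a higher number, and compound 2 gives no number at all. The unmeasured compound 4 `CC1(c2ccccc2)CC(=O)C(C2CC(c3ccc(OCc4ccc(C(F)(F)F)cc4)cc3)Cc3ccccc32)=C(O)O1` keeps the core of compound 3 and differs from it in one place: (4-(trifluoromethyl)benzyl)oxy in place of 4-bromophenyl on an aromatic carbon.

Going by the values given here, only one measured step exists, an at least 1.2-fold higher number from compound 1 to compound 2 (0.08 log units; that floor lies within the scatter), and it concerns a saturated chain carbon on the shared core, not the aromatic end that changes here; it is also bounded by the limit of > 10000 nM in this assay, at which 1 of the 3 values shown sits. Among the compounds with values here, no measured step bears on the replacement of the 4-bromophenyl group, so compound 4 is expected to move little in this assay, with a step of about a 1.4-fold higher number from compound 3 to compound 4 (0.14 log units; within the scatter) that need not exceed the scatter. Compound 4 is thus expected to give roughly 2500 nM in this assay, estimated between 700 nM and 9000 nM.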

Compound 4, half-maximal inhibitory concentration: > 10000 nM
Compound 4: a limit, no number; the forecaster's own chance of this, stated with the estimate: 10%; middle value at least 4.0-fold (0.60 log units) from the limit.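

Going by these compounds alone, the aromatic end of compound 3 proves not to be a silent position in this assay: the only measured change at this place, (4-(trifluoromethyl)benzyl)oxy in place of 4-bromophenyl, gives an at least 5.4-fold higher number from compound 3 to compound 4 (0.73 log units; beyond the scatter). The earlier step on the saturated chain carbon, an at least 1.2-fold higher number from compound 1 to compound 2 (0.08 log units; that floor lies within the scatter), could not be told from the scatter, whereas this one lies beyond it. The value of compound 4 is a limit and not a number, so this step gives only a floor: the limit of > 10000 nM in this assay, at which 2 of the 4 values shown sit.

The compounds shown replace the whole group in a single change, so they do not separate the ether oxygen from the trifluoromethyl group. They also leave open how a small methoxy group, an amine or a carboxylic acid on this aromatic carbon would read in this assay.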